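Three hydrazone aryl groups measured, a fourth one estimated

The compounds below may be only part of what the source reports. "The series", "measured", "known", "first", "only" and "open" are said of these compounds alone.

Measured in a functional assay on NCI-H460 cells (Homo sapiens) for cytotoxicity, read by MTT assay, with a stated time of 72 h; on this read-out lower numbers stand for stronger inhibition and higher numbers for weaker inhibition:
Compound 1 `CN(C)CCn1cnnc1-c1cc(Oc2ccc(NC(=O)N/N=C/c3ccc(Cl)cc3Cl)cc2F)ccn1` gives 130 nM.
Compound 2 `COc1ccc(/C=N/NC(=O)Nc2ccc(Oc3ccnc(-c4nncn4CCN(C)C)c3)c(F)c2)c(OC)c1` gives 1570 nM.
Compound 3 `CN(C)CCn1cnnc1-c1cc(Oc2ccc(NC(=O)N/N=C/c3cccc(Cl)c3Cl)cc2F)ccn1` gives 72 nM.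

Compound 1 stands second highest of the three numbers. Its nearest neighbour is compound 3, with a 1.8-fold lower number from compound 1 to compound 3 (0.26 log units; within the scatter), while compound 2 lies furthest away, with a 12-fold higher number from compound 1 to compound 2 (1.08 log units; beyond the scatter).

Compound 4 `CN(C)CCn1cnnc1-c1cc(Oc2ccc(NC(=O)N/N=C/c3c(O)ccc4ccccc34)cc2F)ccn1` differs from compound 1 in one place: 2-hydroxynaphthalen-1-yl in place of 2,4-dichlorophenyl on a carbon with a double bond to nitrogen. For the measured compounds named here, two measured steps bear on this position. The move to another dichlorophenyl changed little, whereas the move to dimethoxyphenyl raised the number by a large amount. An oxygen-bearing aryl group thus carried a penalty here, so in this assay compound 4 is expected to show a moderately higher number, a 2.7-fold higher number from compound 1 to compound 4 (0.43 log units; beyond the scatter), though the range is wide. Compound 4 is estimated at 350 nM, between 80 nM and 1600 nM.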

Compound 4, half-maximal inhibitory concentration: 890 nM
Estimate against measurement, compound 4: 2.5-fold (0.41 log units) below, and the stated range covers the measured number.
By their numbers in this assay, from the lowest: compounds 3 and 1 (each within the scatter of the next); then compounds 4 and 2 (each within the scatter of the next).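

In this assay the 2-hydroxynaphthalen-1-yl group stands well apart from both dichlorophenyl groups (a 6.8-fold higher number from compound 1 to compound 4 (0.84 log units; beyond the scatter)) and (a 12-fold higher number from compound 3 to compound 4 (1.09 log units; beyond the scatter)) but level with the 2,4-dimethoxyphenyl group (a 1.8-fold lower number from compound 2 to compound 4 (0.25 log units; within the scatter)) in this position on the carbon with a double bond to nitrogen. The higher numbers are therefore not confined to the dimethoxyphenyl group: both oxygen-bearing aryl groups separate from both dichlorophenyl groups, and no compound shown goes against this split. Nothing shown gives a reason for it. As far as these compounds go, whether a phenyl carrying a single hydroxyl, an amine or a carboxylic acid would fall with the dichlorophenyl groups or the oxygen-bearing ones stays open. So does the effect of an unsubstituted naphthalene.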